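Pyrazolo-fused urea series: removing the benzyl group

The source may report more compounds than this note shows. Statements on the series, on what has been measured and on what is new or still open speak of the compounds shown alone.

Measured so far in a functional assay on U-937 cells (Homo sapiens) for inhibition, read by MTT assay, with a stated time of 24 h; on this read-out higher numbers stand for weaker inhibition of growth and lower numbers for stronger inhibition of growth:
compound 1 `O=C1CC(c2ccc(NC(=O)Nc3ccc(Cl)c(C(F)(F)F)c3)cc2)=Nc2cnn(Cc3ccccc3)c2N1`, 8680 nM
compound 2 `COc1ccc(Cn2ncc3c2NC(=O)CC(c2ccc(NC(=O)Nc4ccc(Cl)c(C(F)(F)F)c4)cc2)=N3)cc1`, 7290 nM

Compound 2 gives the lower of the two numbers, yet a 1.2-fold lower number from compound 1 to compound 2 (0.08 log units; within the scatter) is within the scatter, so the two compounds cannot be ordered in this assay. Compound 3 `O=C1CC(c2ccc(NC(=O)Nc3ccc(Cl)c(C(F)(F)F)c3)cc2)=Nc2cn[nH]c2N1` differs from compound 2 by hydrogen in place of 4-methoxybenzyl on an aromatic nitrogen. Within the data shown here, the one measured step, a 1.2-fold lower number from compound 1 to compound 2 (0.08 log units; within the scatter), exchanges a substituent on the benzyl and says little about losing it entirely. The estimated change is a 1.6-fold higher number from compound 2 to compound 3 (0.22 log units; within the scatter), with wide uncertainty. Compound 3 is expected to give 12000 nM, in the range 3500 nM to 40000 nM.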

Compound 3, concentration for 50% growth inhibition: > 30000 nM
Compound 3 ended at the assay's limit (the forecaster's own chance of this, stated with the estimate: 15%); middle value at least 2.5-fold (0.39 log units) from the limit.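

Compound 3 stands only at a limit of the assay, not at a number: the limit of > 30000 nM in this assay, at which 1 of the 3 values shown sits. Losing the whole substituent on this aromatic nitrogen counts, unlike the exchange on the benzyl ring that left compound 1 and compound 2 unordered. Both steps lie beyond the scatter: an at least 4.1-fold higher number from compound 2 to compound 3 (0.61 log units; beyond the scatter), and an at least 3.4-fold higher number from compound 1 to compound 3 (0.53 log units; beyond the scatter).

Going by these compounds, the true size of both steps stays open, since each gives only a minimum. Also open, on these data alone, is whether the aromatic ring is needed here, or whether a methyl group, a longer alkyl chain or an amine-bearing chain on this nitrogen would serve.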